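The source may hold more compounds than are shown below. What is called first, only, known or untested is meant among the compounds shown, and "the series" means these compounds.

Compound 1, `COC(=O)c1ccccc1-c1ccc(CCc2ncc(CC(C)(C)C)n2CC(=O)O)cc1`: 694 nM in an assay on cells for agonist activity at Bombesin receptor subtype-3 (Mus musculus), read by HTRF and inositol phosphate accumulation, with a stated time of 1 h; a lower number here means that less compound is needed, a higher number that more compound is needed for the effect
Compound 2, `COC(=O)c1c(F)cccc1-c1ccc(CCc2ncc(CC(C)(C)C)n2Cc2ccc(C(=O)O)cc2)cc1`: 5 nM in this assay
Compound 3, `CC(C)(C)Cc1cnc(CCc2ccc(-c3cccc(F)c3C(=O)O)cc2)n1Cc1ccc(C(=O)O)cc1`: 13 nM in this assay

Compound 3 stands second highest of the three numbers in this assay: compound 2 lies nearest, compound 1 furthest. Among the compounds with values here, the only measured step between neighbours, a 2.6-fold higher number from compound 2 to compound 3 (0.41 log units; beyond the scatter), concerns the change from methyl ester to free acid on the fluorinated ring and does not touch the group carried on the ring nitrogen of the shared core.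

Compound 4, `CC(C)(C)Cc1cnc(CCc2ccc(-c3cccc(F)c3C(=O)O)cc2)n1CCNS(C)(=O)=O`, differs from compound 3 by (methanesulfonamido)methyl in place of 4-carboxyphenyl on a saturated chain carbon bound to an aromatic nitrogen. Within the data shown here, no measured step bears directly on this change. The nearest hint comes from compound 1 and compound 2, which differ in two places, one of them being the group on that nitrogen: compound 1, carrying a much smaller group there, gives 694 nM, while compound 2, carrying the 4-carboxybenzyl, gives 5 nM. That gap cannot be split between the two differences, but it shows that the nitrogen substituent matters.

Compound 4 is therefore expected to need more compound than compound 3, by roughly a 23-fold higher number from compound 3 to compound 4 (1.36 log units; beyond the scatter). The estimate for compound 4 in this assay is 300 nM, with a range from 50 nM to 2000 nM.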

Compound 4, half-maximal effective concentration: 4 nM
Compound 4: middle estimate off by 75-fold (1.88 log units), on the high side, outside the stated range (below it).
By their numbers in this assay, from the lowest: compounds 4 and 2 (each within the scatter of the next); then compound 3; then compound 1.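

At this position, on a saturated chain carbon bound to an aromatic nitrogen, the 4-carboxyphenyl is not required for a low number: replacing it with (methanesulfonamido)methyl in this assay gives a 3.3-fold lower number from compound 3 to compound 4 (0.51 log units; beyond the scatter). The entering group has no ring and 6 heavy atoms in place of 9, so a shorter, ring-free group with a sulfonamide can take the place of an aromatic acid here without any rise in the number needed for the effect. Nothing available explains why this change lowers the number.

The compounds shown do not separate the contribution of the sulfonamide from that of the two-carbon chain that carries it, so a simple amine, an acetamide or a longer chain ending in the same sulfonamide at this position could each behave differently. They also leave open whether 2-(methanesulfonamido)ethyl would give a similar result with the methyl ester in place of the carboxylic acid on the fluorinated ring, or with that ring's fluorine replaced by hydrogen.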